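Swapping a Pyridine Carbonyl for a Methyl Phenyl Urea

The source may hold more compounds than are shown below. What is called first, only, known or untested is meant among the compounds shown, and "the series" means these compounds.

Of the compounds shown here, three sharing one core have been tested in a functional assay on KB cells (Homo sapiens) for cytotoxicity; a higher number here means a weaker inhibitor, a lower number a stronger inhibitor. Compound 2 `COc1ccc(S(=O)(=O)N2CCc3cccc(NC(=O)c4ccncc4)c32)cc1` gives 9.6 nM and stands lowest of the two numbers, with compound 1 `COc1ccc(S(=O)(=O)N2CCc3cc(Br)cc(NC(=O)c4ccco4)c32)cc1` giving 89 nM as its nearest neighbour. Compound 3 `COc1ccc(S(=O)(=O)N2CCc3cccc(NCc4ccccc4)c32)cc1` reaches only the limit of > 10000 nM in this assay , and so no number is known for it. Going by the values given here, the one step computed between measured compounds is an at least 1000-fold higher number from compound 2 to compound 3 (3.01 log units; beyond the scatter), matching (the limit of > 10000 nM in this assay, at which 1 of the 3 values shown sits).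

Compound 4 `COc1ccc(S(=O)(=O)N2CCc3cccc(NC(=O)N(C)c4ccccc4)c32)cc1` is the unmeasured compound. Against compound 2 it carries methyl(phenyl)amino in place of pyridin-4-yl on a carbonyl carbon. Among the compounds with values here, the carbonyl that compound 3 lacks is kept here, so the collapse from compound 2 to compound 3 does not apply directly; still, the entering methyl(phenyl)amino is a larger change than the one from compound 1 to compound 2. A moderate weakening is expected, a 10-fold higher number from compound 2 to compound 4 (1.02 log units; beyond the scatter). Compound 4 is therefore estimated at 100 nM, within 15 nM to 1500 nM.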

Compound 4, half-maximal inhibitory concentration: > 10000 nM
Compound 4: a limit, no number (the forecaster's own chance of this, stated with the estimate: 15%); at least 100-fold (2.00 log units) between middle value and limit.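

In this assay, keeping the carbonyl does not protect activity: methyl(phenyl)amino in place of pyridin-4-yl on that carbonyl carbon gives an at least 1000-fold higher number from compound 2 to compound 4 (3.01 log units; beyond the scatter). Compound 4 gives > 10000 nM, which is a limit of the assay and not a number. The earlier loss with benzyl therefore cannot be tied to the missing carbonyl alone, since a compound that retains the carbonyl also falls out of range, and the step between compound 3 and compound 4 cannot be read; the assay limit now holds two compounds: the limit of > 10000 nM in this assay, at which 2 of the 4 values shown sit.

Still open, going by these compounds, is which part of the change goes with the loss: the ring nitrogen leaves, while a methyl and an extra nitrogen enter. A plain phenyl or a phenylamino group on the same carbonyl carbon would separate these changes.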